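This account rests on a few compounds, and the source may have more. Where it says the series, first, only, none or still open, it means among the compounds named here.

Measured compounds and their values:
compound 1, `N#CNC(=N)NCCCCCn1nc(-c2ccccc2)ccc1=O`: 31%
compound 2, `C/N=C(\S)NCCCCCn1nc(-c2ccccc2)ccc1=O`: 68.9%
compound 3, `N#CNC(=N)NCCCCn1nc(-c2ccccc2)ccc1=O`: 61.2%

Of the compounds shown here, three have been tested in a functional assay on the whole organism with Rattus norvegicus as the target, at a dose of 100 mg/kg; on this read-out lower numbers stand for less inhibition and higher numbers for more inhibition at the one dose given (going by the name of the read-out). Compound 1 `N#CNC(=N)NCCCCCn1nc(-c2ccccc2)ccc1=O` gives 31% in this assay. Compound 2 `C/N=C(\S)NCCCCCn1nc(-c2ccccc2)ccc1=O` gives 68.9%, and compound 3 `N#CNC(=N)NCCCCn1nc(-c2ccccc2)ccc1=O` gives 61.2% in the same read-out.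

Two steps stand beyond the scatter. The change from compound 1 to compound 2 is a group of 4 heavy atoms (2 carbon, 1 nitrogen, 1 sulfur; no ring) in place of a group of 5 heavy atoms (2 carbon, 3 nitrogen; no ring), on an amine nitrogen; it made a number 37.9 percentage points higher from compound 1 to compound 2 (beyond the scatter). The change from compound 1 to compound 3 is a group of 6 heavy atoms (2 carbon, 4 nitrogen; no ring) in place of a group of 7 heavy atoms (3 carbon, 4 nitrogen; no ring), on a saturated chain carbon, four bonds along the chain from an aromatic nitrogen; it made a number 30.2 percentage points higher from compound 1 to compound 3 (beyond the scatter). Compound 2 and compound 3 differ by a number 7.7 percentage points lower from compound 2 to compound 3 (within the scatter), so their values show no difference that can be read.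

Compound 4 `C/N=C(\S)NCCCCn1nc(-c2ccccc2)ccc1=O` has not yet been measured. It differs from compound 3 by a group of 4 heavy atoms (2 carbon, 1 nitrogen, 1 sulfur; no ring) in place of a group of 5 heavy atoms (2 carbon, 3 nitrogen; no ring), on an amine nitrogen. This is the same change that was made from compound 1 to compound 2, carried out on a core that differs from the core of compound 1 by a group of 6 heavy atoms (2 carbon, 4 nitrogen; no ring) in place of a group of 7 heavy atoms (3 carbon, 4 nitrogen; no ring), on a saturated chain carbon, four bonds along the chain from an aromatic nitrogen. Because that earlier step was a number 37.9 percentage points higher from compound 1 to compound 2 (beyond the scatter), and because compound 3 already gives 61.2%, the step from compound 3 to compound 4 in this assay is expected to be a number 20.8 percentage points higher from compound 3 to compound 4 (beyond the scatter), smaller than the earlier one. The estimate for compound 4 in this assay is therefore 82%, expected to lie between 65% and 97%.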

Compound 4, a percentage reported as inhibition, in the whole organism at one dose (the size of the read-out at that dose, not a potency): 87.1%
Estimate against measurement, compound 4: 5.1 percentage points below; low and high end bracket the measured number.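

In this assay, replacing the nitrile-bearing group on the amine nitrogen with the sulfur-bearing group gave a number 25.9 percentage points higher from compound 3 to compound 4 (beyond the scatter), so the change carried over to the shorter-chain core in the same direction and with a size that cannot be told apart from the earlier step: the same change on two cores in this assay, a number 37.9 percentage points higher (beyond the scatter) from compound 1 to compound 2 and a number 25.9 percentage points higher (beyond the scatter) from compound 3 to compound 4, 12 percentage points apart, within the scatter of two such steps. Compound 4 also stands clear of the two longer-chain compounds, with a number 18.2 percentage points higher from compound 2 to compound 4 (beyond the scatter) for the chain change alone and a number 56.1 percentage points higher from compound 1 to compound 4 (beyond the scatter) for the chain change together with the change of group. This shows that the change held on these two cores, which differ only in chain length, but it does not show that the two steps are equal in size, nor that the change would hold on a core altered elsewhere, and a single dose in the whole organism says nothing about potency.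

The compounds shown leave open whether the same change holds with a chain shorter than that of compound 4 or longer than that of compound 1. They also leave open how a urea or a simple amine on the same nitrogen would compare, and what happens when the phenyl ring carries a substituent such as chlorine or methoxy.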